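Ethyl urea in place of a chloroalkyl amide

The source may report more compounds than this note shows. Statements on the series, on what has been measured and on what is new or still open speak of the compounds shown alone.

compound 1, `CC(=O)Nc1ccc(S(=O)(=O)Oc2ccccc2C(C)C)cc1`: 21000 nM
compound 2, `CC(C)c1ccccc1OS(=O)(=O)c1ccc(NC(=O)CCCl)cc1`: 14000 nM
compound 3, `CC(C)c1ccccc1OS(=O)(=O)c1ccc(NC(=O)CCCCl)cc1`: 5100 nM

All three were tested in a functional assay on M21 cells (Homo sapiens) for antiproliferative activity, read by sulforhodamine B assay, with a stated time of 48 h; on this read-out higher numbers stand for weaker inhibition and lower numbers for stronger inhibition. Compound 3 gives the lowest number of the three: the steps of a 2.7-fold lower number from compound 2 to compound 3 (0.44 log units; beyond the scatter) and a 4.1-fold lower number from compound 1 to compound 3 (0.61 log units; beyond the scatter) both lie beyond the scatter, while a 1.5-fold lower number from compound 1 to compound 2 (0.18 log units; within the scatter) does not. Compound 4, `CCNC(=O)Nc1ccc(S(=O)(=O)Oc2ccccc2C(C)C)cc1`, has not been measured. Its change from compound 3 is ethylamino in place of 3-chloropropyl on a carbonyl carbon. Going by the values given here, no measured step swaps the chain for an amine, so none bears on it directly; the measured steps only show that longer chloroalkyl chains gave lower numbers, each by a modest amount. The expected step of a 2.9-fold higher number from compound 3 to compound 4 (0.47 log units; beyond the scatter) in this assay is therefore a tentative rise. Compound 4 is estimated at about 15000 nM, between 5000 nM and 45000 nM.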

Compound 4, half-maximal inhibitory concentration: 4700 nM
Estimate against measurement, compound 4: 3.2-fold (0.50 log units) above; measured number below the stated range.
By their numbers in this assay, from the lowest: compounds 4 and 3 (each within the scatter of the next); then compounds 2 and 1 (each within the scatter of the next).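

In this assay there is a 1.1-fold lower number from compound 3 to compound 4 (0.04 log units; within the scatter) and so ethylamino on the carbonyl carbon does as well as 3-chloropropyl, which shows that a chlorine-bearing chain is not required for a number at this level. The ethylamino group also keeps the modest gaps to the smaller groups, with a 3.0-fold lower number from compound 2 to compound 4 (0.47 log units; beyond the scatter) and a 4.5-fold lower number from compound 1 to compound 4 (0.65 log units; beyond the scatter) both beyond the scatter. No measurement here explains why these groups give these numbers. As far as these compounds go, whether a longer chain such as butylamino, or a chlorine-bearing 2-chloroethylamino group, would lower the number further remains open.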